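Cyano for Chloro on the Pendant Phenyl Ring

The source may hold more compounds than are shown below. What is called first, only, known or untested is meant among the compounds shown, and "the series" means these compounds.

Compound 1 `COc1ccccc1-n1nc(C2CC(C)(C)OC(C)(C)C2)cc1-c1ccc(Cl)cc1` is the reference point of this set. In an assay on HEK293 cells for inhibition of Voltage-dependent N-type calcium channel subunit alpha-1B (Homo sapiens), read by patch clamp, using a membrane potential dye (on this read-out lower numbers stand for stronger inhibition and higher numbers for weaker inhibition), compound 1 gives 16 nM, the lowest of the two numbers reported. Compound 3 `CC1(C)CC(c2cc(-c3ccc(Cl)cc3)n(-c3ccncc3)n2)CC(C)(C)O1` differs from it by pyridin-4-yl in place of 2-methoxyphenyl on an aromatic nitrogen; in this assay compound 3 gives 22000 nM, so the step of a 1400-fold higher number from compound 1 to compound 3 (3.14 log units; beyond the scatter) is large. For compound 2 `COc1ccccc1-n1nc([C@@H]2CCO[C@@H](C(C)C)C2)cc1-c1ccc(Cl)cc1` the result in this assay is "not determined" (no result reported).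

Compound 4 `COc1ccccc1-n1nc(C2CC(C)(C)OC(C)(C)C2)cc1-c1ccc(C#N)cc1` has not yet been measured. It differs from compound 1 as follows: cyano in place of chloro on an aromatic carbon. Among the compounds with values here, the single measured step concerns the group on the aromatic nitrogen and says nothing about the substituent on the phenyl ring; no measured pair varies that place. Within the data shown here, with no step to lean on, the change from chloro to cyano is expected to leave the number close to that of compound 1, within the scatter. Compound 4 is therefore expected to give 25 nM, in a range from 8 nM to 80 nM. The expected step is a 1.6-fold higher number from compound 1 to compound 4 (0.19 log units; within the scatter).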

Compound 4, half-maximal inhibitory concentration: 85 nM
Compound 4: middle estimate off by 3.4-fold (0.53 log units), on the low side; measured number above the stated range.
By their numbers in this assay, from the lowest: compound 1; then compound 4; then compound 3.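

The place para to a large group on the phenyl ring is not silent: in this assay, cyano in place of chloro gives a 5.3-fold higher number from compound 1 to compound 4 (0.73 log units; beyond the scatter), so this position registers a change of substituent, though only a modest one. That step is much smaller than the one on the aromatic nitrogen, a 1400-fold higher number from compound 1 to compound 3 (3.14 log units; beyond the scatter), which makes the phenyl substituent the more forgiving of the two places varied so far. Nothing measured here bears on why the number rises with cyano.

With only chloro and cyano at this place, two points cannot show a trend across substituents. Going by these compounds, whether fluoro, methyl, methoxy or an amine would stay as close to compound 1 as the number allows, or fall further away than cyano, remains open.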